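The source may report more compounds than this note shows. Statements on the series, on what has been measured and on what is new or still open speak of the compounds shown alone.

Three compounds have been measured in an assay on membranes from CHO cells for displacement of a labelled ligand from adenosine receptor A1 (Homo sapiens), read by scintillation counting, with a stated time of 60 min, tested at 1 uM; on this read-out lower numbers stand for less inhibition and higher numbers for more inhibition at the one concentration tested (going by the name of the read-out):

compound 1 `CC1=C(C(=O)OC(C)(C)C)C(c2cccs2)NC(=S)N1` gives 22%
compound 2 `CC1=C(C(=O)OCc2ccccc2)C(c2cccs2)NC(=S)N1` gives 34%
compound 3 `CC1=C(C(=O)OC(C)(C)C)C(c2cccs2)NC(=O)N1C` gives 18%

Compound 1 and compound 2 share a core and differ in one place: benzyl in place of tert-butyl on an oxygen next to a carbonyl group. In this assay this change gives a number 12 percentage points higher from compound 1 to compound 2 (beyond the scatter). Compound 3 has a different core; how its core differs from that of compound 1 is not broken down here. Compound 3 and compound 1 give numbers within the scatter of each other, so no order between them can be read.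

Compound 4 `CC1=C(C(=O)OCc2ccccc2)C(c2cccs2)NC(=O)N1C` has not yet been measured. It stands to compound 3 as compound 2 stands to compound 1: benzyl in place of tert-butyl on an oxygen next to a carbonyl group. The place of the change is the same in both pairs, so it is the same change made on a second core.

In this assay, among the compounds with values here, the step from compound 3 to compound 4 is expected to be a number 12 percentage points higher from compound 3 to compound 4 (beyond the scatter) because a number 12 percentage points higher from compound 1 to compound 2 (beyond the scatter) is the one step of this kind that has been seen. Within the data shown here, the room left either way is wide: only that single modest step stands behind the expectation. Compound 4 is therefore estimated at 30%, between 15% and 45%.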

Compound 4, a percentage reported as inhibition, at one concentration (the size of the read-out at that concentration, not a potency): 50%
The estimate for compound 4 lay 20 percentage points below the measured number; the measured number lies above the stated range.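

In this assay, putting benzyl in place of tert-butyl on the second core gives a number 32 percentage points higher from compound 3 to compound 4 (beyond the scatter). The direction of the change therefore carries over from one core to the other, but its size does not: the same change on two cores in this assay, a number 12 percentage points higher (beyond the scatter) from compound 1 to compound 2 and a number 32 percentage points higher (beyond the scatter) from compound 3 to compound 4, 20 percentage points apart, beyond the scatter of two such steps. This shows that the size of a step seen on one core cannot simply be added to a compound on another core in this series, but two pairs give no general rule, and they do not show which part of the difference between the cores goes with the larger step.

The compounds shown carry only tert-butyl and benzyl on the oxygen next to the carbonyl group, so it remains open how a methyl group, an ethyl group or a longer chain ending in a phenyl ring would read on either core. Going by these compounds, it also remains open whether a chain bearing an amine would keep the same direction on both cores.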